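Swapping the amide aryl group for a pyrimidine

The compounds below may be only part of what the source reports. "The series", "measured", "known", "first", "only" and "open" are said of these compounds alone.

The series rests on a shared core that carries an amide; compound 1 `COc1cccc(C(=O)Nc2ccc(Cl)cc2CN2C(=O)c3ccccc3C2=O)c1` is one member of it. In an assay on CHO cells for positive allosteric modulation of metabotropic glutamate receptor 5 (Homo sapiens), read by FLIPR (a lower number here means that less compound is needed, a higher number that more compound is needed for the effect), compound 1 gives 1500 nM, the lowest of the two numbers available. Compound 2 `Cc1ccc2c(c1C)C(=O)N(Cc1cc(Cl)ccc1NC(=O)c1ccccn1)C2=O` differs from it in the substitution of the core and in the group on the amide carbonyl; in this assay compound 2 gives 2200 nM, which sits within the usual scatter of the value for compound 1, so no order between the two can be read from these numbers. Compound 3 `COc1ccc2c(c1OC)C(=O)N(Cc1cc(Cl)ccc1NC(=O)c1ccccn1)C2=O` carries two methoxy groups on the core, and in this assay compound 3 reaches only a limit, > 100000 nM, rather than a number; one of the three results shown sits at that limit (the limit of > 100000 nM in this assay, at which 1 of the 3 values shown sits).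

Compound 4 `O=C(Nc1ccc(Cl)cc1CN1C(=O)c2ccccc2C1=O)c1ncccn1` has not yet been measured. It is derived from compound 1 by a single change: pyrimidin-2-yl in place of 3-methoxyphenyl on a carbonyl carbon. Among the measured compounds shown here, no pair of measured compounds shows the effect of this exact change, so the size of the step can only be guessed. With compound 2 showing 2200 nM for a related core carrying a six-membered heteroaromatic ring on the carbonyl, the step is expected to be small, either none beyond the scatter or a modest move towards a higher number. The expected step of a 1.7-fold higher number from compound 1 to compound 4 (0.22 log units; within the scatter) reflects this. Compound 4 is accordingly estimated at 2500 nM, with a plausible range from 800 nM to 8000 nM.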

Compound 4, half-maximal effective concentration: 2100 nM
Estimate against measurement, compound 4: 1.2-fold (0.08 log units) above; low and high end bracket the measured number.
By their numbers in this assay, from the lowest: compounds 1, 4 and 2 (each within the scatter of the next). At a limit, above all of these: compound 3.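

Among the compounds shown here, this gives the first reading of a single change on this carbonyl carbon, whose other neighbour is the amide-type nitrogen, as no earlier pair differed in one place only. In this assay, for the compounds shown here, pyrimidin-2-yl in place of 3-methoxyphenyl gives a 1.4-fold higher number from compound 1 to compound 4 (0.15 log units; within the scatter), so a six-membered aromatic ring of carbon only that bears a methoxy group can give way to a six-membered aromatic ring with hetero atoms without a shift beyond the scatter. No measured property shown here accounts for this result.

The compounds shown leave open whether pyrimidin-2-yl behaves the same way on a substituted core, since it appears only on the core of compound 1, and how a non-aromatic group on this carbonyl carbon, such as an amine like morpholine or a carboxylic acid, would read in this assay. Compound 3 stands at a limit, > 100000 nM, and with no single-change partner for it, the compounds shown do not tell which part of its structure goes with that limit.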